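The source may report more compounds than this note shows. Statements on the series, on what has been measured and on what is new or still open speak of the compounds shown alone.

In a functional assay for inhibition of nuclear factor NF-kappa-B complex (Homo sapiens) (on this read-out higher numbers stand for weaker inhibition and lower numbers for stronger inhibition), compound 1 `COc1ccc2c(c1)OC(c1cc(OC)c(OC)c(OC)c1)C(C(C)=O)=C2` gives 14100 nM. Compound 2 `CNC(=O)C1=Cc2ccc(OC)cc2OC1c1cc(OC)c(OC)c(OC)c1` reaches only a limit of this assay, > 50000 nM. Compound 3 `CCOCC1=Cc2ccc(OC)cc2OC1c1cc(OC)c(OC)c(OC)c1` gives 21300 nM, the highest of the two numbers; the nearest number stands a 1.5-fold higher number from compound 1 to compound 3 (0.18 log units; within the scatter), and the other shown step is an at least 2.3-fold lower number from compound 2 to compound 3 (0.37 log units; beyond the scatter). Compound 4 `COc1ccc2c(c1)OC(c1cc(OC)c(OC)c(OC)c1)C(CO)=C2` differs from compound 3 by hydrogen in place of ethyl on an oxygen on a saturated carbon. Going by the values given here, no measured step alters this oxygen substituent; the steps that touch the same double-bonded ring carbon, a 1.5-fold higher number from compound 1 to compound 3 (0.18 log units; within the scatter) and an at least 2.3-fold lower number from compound 2 to compound 3 (0.37 log units; beyond the scatter), were within the scatter or modest, so there is no ground for a large shift. For compound 4 only a small step is expected, a 1.1-fold lower number from compound 3 to compound 4 (0.03 log units; within the scatter), in no firm direction. Compound 4 is estimated at 20000 nM, between 8000 nM and 50000 nM.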

Compound 4, half-maximal inhibitory concentration: > 50000 nM
Compound 4 gave a limit, no number; the forecaster's own chance of this, stated with the estimate: 15%; at least 2.5-fold (0.39 log units) between middle value and limit.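

In this assay, going by these compounds alone, removing the ethyl from this oxygen gives an at least 2.3-fold higher number from compound 3 to compound 4 (0.37 log units; beyond the scatter), so the oxygen substituent, which no earlier step touched, does move the read-out. On the double-bonded ring carbon, hydroxymethyl shows an at least 3.5-fold higher number from compound 1 to compound 4 (0.54 log units; beyond the scatter), whereas ethoxymethyl shows only a 1.5-fold higher number from compound 1 to compound 3 (0.18 log units; within the scatter). Compound 4 gives a limit, not a number, and the step from compound 2 to compound 4 cannot be read: the limit of > 50000 nM in this assay, at which 2 of the 4 values shown sit.

Going by these compounds, whether a longer chain such as propyl on this oxygen would keep the number or lower it stays open. So does the effect of an amine in place of this oxygen.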